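Moving the ring nitrogen one position on compound 1

This account rests on a few compounds, and the source may have more. Where it says the series, first, only, none or still open, it means among the compounds named here.

Compound 1 `Nc1ccccc1NC(=O)c1ccc(CSC(=S)N2CCN(Cc3ccccn3)CC2)cc1` carries a benzamide core with a dithiocarbamate linker and a piperazine ring, on which a (pyridin-2-yl)methyl group sits. In a functional assay on A-375 cells (Homo sapiens) for antiproliferative activity, read by CCK-8 assay, with a stated time of 72 h, tested at 8 uM (on this read-out lower numbers stand for a weaker effect and higher numbers for a stronger effect at the one concentration tested), compound 1 gives 82.4%, the highest of the three numbers shown. Compound 3 `Nc1ccccc1NC(=O)c1ccc(CSC(=S)N2CCCc3ccccc32)cc1` gives 81.5% in this assay, a value within the scatter of compound 1, so the two cannot be ordered. Compound 2 `Nc1ccccc1NC(=O)c1ccc(CSC(=S)N2CCc3cc([N+](=O)[O-])ccc32)cc1` gives 29.5%, well below compound 1 and beyond the scatter.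

Compound 4 `Nc1ccccc1NC(=O)c1ccc(CSC(=S)N2CCN(Cc3cccnc3)CC2)cc1` is the unmeasured partner of compound 1. The two share every atom; they differ only in pyridin-3-yl in place of pyridin-2-yl on a saturated chain carbon bound to an amine nitrogen in a ring. The ring nitrogen of the pendant pyridine simply sits at a different position of that ring.

Among the measured compounds shown here, no measured pair shows what this kind of change does in this assay. The expectation is therefore a step from compound 1 to compound 4 of small size, most likely none beyond the scatter, with a slight lean downward allowed. The measured compounds give no sign that the pendant ring position drives the number. Compound 4 is expected to reach about 76%, estimated between 58% and 90%, which means an expected step of a number 6.4 percentage points lower from compound 1 to compound 4 (within the scatter) in this assay.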

Compound 4, a percentage reported as inhibition, at one concentration (the size of the read-out at that concentration, not a potency): 89.2%
For compound 4 the middle estimate is 13.2 percentage points below the measured one; the measured number falls inside the stated range.
By their numbers in this assay, from the lowest: compound 2; then compounds 3, 1 and 4 (each within the scatter of the next).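

Among the compounds shown here, the first measured pair for this change shows a number 6.8 percentage points higher from compound 1 to compound 4 (within the scatter) in this assay and so gives a direct reading of this position: pyridin-3-yl in place of pyridin-2-yl on a saturated chain carbon bound to an amine nitrogen in a ring does not separate the two compounds. In this one pair, the ring nitrogen of the pendant pyridine can sit at either position without a step beyond the usual scatter at the single concentration tested. No supporting data are available to explain why the two compounds read alike.

The compounds shown leave open whether pyridin-4-yl or a plain phenyl ring at the same place would also read alike. A single concentration also gives no potency, so compound 1 and compound 4 could still differ across a full concentration range.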